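Hydroxy Addition and Cytotoxicity Across Two Related Cores

A few compounds are considered here, and "the series" means these few. Any claim that something is new, unique, unknown or untested is made for them only; others in the source may bear on it.

Compound 1 `CC(C)NC(=N)c1ccc(-c2cc3cc(C(=N)NC(C)C)ccc3o2)cc1` in an ADME assay on L6 cells (Rattus norvegicus) for cytotoxicity (on this read-out lower numbers stand for stronger inhibition and higher numbers for weaker inhibition), gives > 198000 nM, a limit of the assay.
Compound 2 `CC(C)NC(=N)c1ccc(-c2cc3cc(C(=N)NC(C)C)cc(O)c3o2)cc1` in this assay gives > 185000 nM, a limit of the assay.
Compound 3 `Oc1cc(C2=NCCN2)cc2cc(-c3ccc(C4=NCCN4)cc3)oc12` in this assay gives > 203000 nM, a limit of the assay.

The change from compound 1 to compound 2 is hydroxy in place of hydrogen on an aromatic carbon, and the step it made is a step that the two limits leave unreadable from compound 1 to compound 2, unreadable because the limit of > 198000 nM in this assay, at which 1 of the 3 values shown sits, and the limit of > 185000 nM in this assay, at which 1 of the 3 values shown sits, bound both values. Compound 4 `Oc1cc(C2=NCCN2)ccc1-c1cc2cc(C3=NCCN3)cc(O)c2o1` is not yet measured; it differs from compound 3 by hydroxy in place of hydrogen on an aromatic carbon, the same kind of change, though here the six-membered ring is not part of a fused system and the hydroxy sits ortho to a large group and meta to a group of 5 heavy atoms. The difference between the cores of compound 1 and compound 3 is not broken down here. In this assay the step is expected to be a step that the limit leaves unreadable from compound 3 to compound 4, resting on compound 3 sitting at the limit of > 203000 nM in this assay, at which 1 of the 3 values shown sits, and on compound 2 sitting at the limit of > 185000 nM in this assay, at which 1 of the 3 values shown sits. Compound 4 is therefore estimated at 250000 nM, most probably again reported only as a limit.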

Compound 4, half-maximal inhibitory concentration: > 193000 nM
Compound 4: only a limit was reported; the forecaster's own chance of this, stated with the estimate: 85%; the middle value does not contradict the limit.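

Compound 3 and compound 4 are both reported only as limits in this assay, so no step can be read between them. The compounds shown leave open what hydroxy in place of hydrogen changes on either core.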